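A larger sulfonamide arm in place of cyclopropyl

A few compounds are considered here, and "the series" means these few. Any claim that something is new, unique, unknown or untested is made for them only; others in the source may bear on it.

Going by the values given here, compound 2 `O=C1O[C@H]([C@@H](O)Cn2cc(C3CC3)nn2)C(OCc2ccccc2)=C1OCc1ccccc1` holds the only firm number in a functional assay on A549 cells (Homo sapiens) for antiproliferative activity, read by MTT assay, with a stated time of 72 h (on this read-out lower numbers stand for stronger inhibition and higher numbers for weaker inhibition), giving 43900 nM. Compound 1 `COc1ccccc1-c1cn(C[C@H](O)[C@H]2OC(=O)C(OCc3ccccc3)=C2OCc2ccccc2)nn1` reaches only a limit there, > 100000 nM. Among the compounds with values here, the single measured comparison is an at least 2.2-fold lower number from compound 1 to compound 2 (0.35 log units; beyond the scatter). Compound 3 `Cc1ccc(S(=O)(=O)NCc2cn(C[C@H](O)[C@H]3OC(=O)C(OCc4ccccc4)=C3OCc3ccccc3)nn2)cc1` carries (((4-methylphenyl)sulfonyl)amino)methyl in place of cyclopropyl on an aromatic carbon. Within the data shown here, that one step is the only guide, and the new change runs in the opposite sense, bringing back an aromatic group together with a donor and acceptors. A modest rise toward the limit is therefore expected, a 1.6-fold higher number from compound 2 to compound 3 (0.20 log units; within the scatter). Compound 3 is estimated at 70000 nM, with a range from 25000 nM to 200000 nM.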

Compound 3, half-maximal inhibitory concentration: 16800 nM
Estimate against measurement, compound 3: 4.2-fold (0.62 log units) above; the measured number lies below the stated range.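

In this assay, this aromatic carbon accepts a far larger arm than cyclopropyl, and the (((4-methylphenyl)sulfonyl)amino)methyl group gives a 2.6-fold lower number from compound 2 to compound 3 (0.42 log units; beyond the scatter). An aromatic ring at this place is therefore not a drawback in itself, as the same arm in place of 2-methoxyphenyl gives an at least 5.9-fold lower number from compound 1 to compound 3 (0.77 log units; beyond the scatter). That second step is open-ended, since one end of it is a limit: the limit of > 100000 nM in this assay, at which 1 of the 3 values shown sits.

Which part of the arm carries the gain stays open. So does whether a simple aminomethyl or benzyl group would keep it.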